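This account rests on a few compounds, and the source may have more. Where it says the series, first, only, none or still open, it means among the compounds named here.

In a functional assay on CWR22R cells (Homo sapiens) for inhibition (a higher number here means a weaker inhibitor, a lower number a stronger inhibitor), compound 1 `CCn1c(=O)/c(=C2\Sc3ccccc3N2C)s/c1=C\c1ccncc1Nc1ccccc1F` gives 300 nM. Compound 3 `CCn1c(=O)/c(=C2\Sc3ccccc3N2C)s/c1=C\c1ccncc1Nc1ccccc1Cl` gives 460 nM, and the two sit together at the low end of the three numbers, with a 1.5-fold higher number from compound 1 to compound 3 (0.19 log units; within the scatter). Compound 2 `CCn1c(=O)/c(=C2\Sc3ccccc3N2C)s/c1=C\c1ccncc1Nc1cc(C)ccc1C` gives 1800 nM and stands apart, with a 6.0-fold higher number from compound 1 to compound 2 (0.78 log units; beyond the scatter). The return from that compound shows a 3.9-fold lower number from compound 2 to compound 3 (0.59 log units; beyond the scatter).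

Compound 4 `CCn1c(=O)/c(=C2\Sc3ccc(OC)cc3N2C)s/c1=C\c1ccncc1Nc1ccccc1F` keeps the 2-fluorophenyl group of compound 1 and changes the shared core: methoxy in place of hydrogen on an aromatic carbon. This is methoxy in place of hydrogen on an aromatic carbon, on a six-membered aromatic ring of carbon only that is part of a fused or bridged system of two rings.

All three measured steps change the aryl group on the nitrogen, and none touches the ring that takes the methoxy. They therefore give no direct reading of this change and serve only as a rough guide to how far a single change can move the number here. With no evidence for a direction, no step beyond the scatter is expected, though the range is kept wide. The expected result is a 1.1-fold higher number from compound 1 to compound 4 (0.05 log units; within the scatter). For compound 4 the estimated value is 340 nM, with an expected range from 120 nM to 950 nM.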

Compound 4, half-maximal inhibitory concentration: 190 nM
For compound 4 the middle estimate is 1.8-fold (0.25 log units) above the measured one; measured number inside the range.
By their numbers in this assay, from the lowest: compounds 4, 1 and 3 (each within the scatter of the next, the first and the last beyond it); then compound 2.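

Within the data shown here, the earlier compounds changed only the aryl group on the nitrogen, so compound 4 gives the first reading of a change on the six-membered aromatic ring of carbon only in the shared core. In this assay, methoxy in place of hydrogen on this ring gives a 1.6-fold lower number from compound 1 to compound 4 (0.20 log units; within the scatter), so with the 2-fluorophenyl group in place, this carbon accepts a methoxy group without a step beyond the usual scatter of the measurement. Nothing among the data shown explains this result, and the step alone cannot separate a real gain from repeat-to-repeat variation.

The compounds shown leave open whether this carbon would accept an amine, a carboxylic acid or a longer chain such as butoxy as readily as methoxy, and whether a methoxy group on the other carbons of the same ring would give a similar number. They also leave open whether the methoxy group would give a similar step alongside the 2-chlorophenyl or 2,5-dimethylphenyl group, since it appears here only with the 2-fluorophenyl group.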